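This account rests on a few compounds, and the source may have more. Where it says the series, first, only, none or still open, it means among the compounds named here.

Working notes on the quinoline thiosemicarbazone series. Compound 1 `S=C(N/N=C/c1ccc2ccccc2n1)Nc1ccc(Cl)cc1` carries a 4-chlorophenyl on the amide-type nitrogen. In a functional assay on HeLa cells (Homo sapiens) for antiproliferative activity, read by sulforhodamine B assay, with a stated time of 72 h (on this read-out higher numbers stand for weaker inhibition and lower numbers for stronger inhibition), compound 1 returns only a limit, > 100000 nM. That reading sits at the limit of > 100000 nM in this assay, at which 1 of the 3 values shown sits. Compound 2 `Fc1ccc(NC(=S)N/N=C/c2ccc3ccccc3n2)cc1` differs by fluoro in place of chloro on an aromatic carbon, and in this assay compound 2 gives 33200 nM; this is an at least 3.0-fold lower number from compound 1 to compound 2 (0.47 log units; beyond the scatter). Compound 3 `S=C(N/N=C/c1ccc2ccccc2n1)Nc1cccc(Cl)c1` is the isomer of compound 1, with the difference (3-chlorophenyl in place of 4-chlorophenyl on an amide-type nitrogen); in this assay compound 3 gives 52500 nM, which is an at least 1.9-fold lower number from compound 1 to compound 3 (0.27 log units; that floor lies within the scatter). Between compound 2 and compound 3 the step is a 1.6-fold higher number from compound 2 to compound 3 (0.20 log units; within the scatter).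

Compound 4 `Fc1cccc(NC(=S)N/N=C/c2ccc3ccccc3n2)c1` remains to be measured. It differs from compound 3 by fluoro in place of chloro on an aromatic carbon. This is the same kind of change as that from compound 1 to compound 2, but there the fluoro sits para to a large group, here meta to a large group. On the basis of an at least 3.0-fold lower number from compound 1 to compound 2 (0.47 log units; beyond the scatter), a step in the same direction is expected for compound 4, estimated at a 2.1-fold lower number from compound 3 to compound 4 (0.32 log units; beyond the scatter). Compound 3 already starts from a number rather than a limit, and a smaller step than that from compound 1 to compound 2 is expected. For compound 4 in this assay the expected value is 25000 nM, somewhere between 8000 nM and 80000 nM.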

Compound 4, half-maximal inhibitory concentration: 70100 nM
Compound 4: the middle estimate sits 2.8-fold (0.45 log units) below what was measured; low and high end bracket the measured number.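

The change of chloro to fluoro does not carry from one core to the other in this assay: the same change on two cores in this assay, an at least 3.0-fold lower number (0.47 log units; beyond the scatter) from compound 1 to compound 2 and a 1.3-fold higher number (0.13 log units; within the scatter) from compound 3 to compound 4, at least 4.0-fold (0.60 log units) apart, beyond the scatter of two such steps

With the halogen on the 3-substituted phenyl, the step is a 1.3-fold higher number from compound 3 to compound 4 (0.13 log units; within the scatter), so chloro and fluoro cannot be told apart there, while 3-fluorophenyl in place of 4-fluorophenyl gives a 2.1-fold higher number from compound 2 to compound 4 (0.32 log units; beyond the scatter) and 3-fluorophenyl in place of 4-chlorophenyl gives an at least 1.4-fold lower number from compound 1 to compound 4 (0.15 log units; that floor lies within the scatter). On these data alone, compound 1 stands at a limit, > 100000 nM, so the full size of its steps is unknown, and these few compounds do not show why the two chloro-to-fluoro steps part or whether either would hold for another halogen.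

Open, as far as these compounds go, is whether a bromo, methoxy or trifluoromethyl group in place of the halogen would follow the step seen on the 4-substituted phenyl or the one seen on the 3-substituted phenyl. Also open is whether a dimethylamino group or a carboxylic acid on that phenyl would give stronger inhibition than the halogens shown.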